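The source may hold more compounds than are shown below. What is called first, only, known or untested is meant among the compounds shown, and "the series" means these compounds.

Working notes on the series. Of the compounds shown here, three have been measured in a functional assay on MCF7 cells (Homo sapiens) for antiproliferative activity, read by MTT assay, with a stated time of 72 h; a lower number here means a stronger inhibitor, a higher number a weaker inhibitor. Compound 1 `O=[N+]([O-])c1ccc(COc2ccc(Nc3ncnc4cc5c(cc34)OCCOCCOCCOCCO5)cc2)cc1` carries the longer fused chain and the (4-nitrobenzyl)oxy group. In this assay compound 1 gives only a limit of the assay, > 100000 nM. Compound 2 `O=[N+]([O-])c1ccc(COc2cccc(Nc3ncnc4cc5c(cc34)OCCOCCO5)c2)cc1` has a shorter fused chain and a different core; in this assay compound 2 gives 42400 nM. Compound 3 `c1ccc(COc2cccc(Nc3ncnc4cc5c(cc34)OCCOCCO5)c2)cc1` is its benzyloxy counterpart, and in this assay compound 3 gives 40900 nM. The step of a 1.0-fold lower number from compound 2 to compound 3 (0.02 log units; within the scatter) belongs to the change (hydrogen in place of nitro on an aromatic carbon). How the core of compound 1 differs from the core of compound 2 is not broken down here.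

Compound 4 `c1ccc(COc2ccc(Nc3ncnc4cc5c(cc34)OCCOCCOCCOCCO5)cc2)cc1` is not yet measured. It differs from compound 1 by hydrogen in place of nitro on an aromatic carbon, which is the same change as that from compound 2 to compound 3; the place is described in the same words in both cases, and among the compounds shown the change occurs twice in all.

For compound 4 the expected step is a step that the limit leaves unreadable from compound 1 to compound 4, resting on a 1.0-fold lower number from compound 2 to compound 3 (0.02 log units; within the scatter). Compound 1 sits at the limit of > 100000 nM in this assay, at which 1 of the 3 values shown sits, so compound 4 is expected most likely to come back as a limit as well. Compound 4 is estimated at 150000 nM, with a range from 70000 nM to 400000 nM.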

Compound 4, half-maximal inhibitory concentration: 12000 nM
For compound 4 the middle estimate is 13-fold (1.10 log units) above the measured one; measured number below the stated range.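

In this assay the change from (4-nitrobenzyl)oxy to benzyloxy does not carry over in size from one core to the other, with an at least 8.3-fold lower number from compound 1 to compound 4 (0.92 log units; beyond the scatter) set against a 1.0-fold lower number from compound 2 to compound 3 (0.02 log units; within the scatter), and the two steps differ: the same change on two cores in this assay, a 1.0-fold lower number (0.02 log units; within the scatter) from compound 2 to compound 3 and an at least 8.3-fold lower number (0.92 log units; beyond the scatter) from compound 1 to compound 4, at least 8.0-fold (0.90 log units) apart, beyond the scatter of two such steps

The step on the core of compound 1 is open-ended, as compound 1 stands at a limit of the assay and not at a number, so the true size of that step remains unknown and only its printed lower bound can be used: the limit of > 100000 nM in this assay, at which 1 of the 4 values shown sits.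

The two pairs show that the effect of this change in the series depends on the core it is made on, but they do not show which feature of the cores goes with the gap, and two pairs give no rule for any further core.

The compounds shown leave open whether the gap goes with the longer fused chain or with another feature of the core of compound 1, since the two cores differ in more than one place. Also open, going by these compounds, is whether another group in place of nitro, such as an amine or a carboxylic acid, would give steps that differ between the two cores in the same way.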